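The source may report more compounds than this note shows. Statements on the series, on what has been measured and on what is new or still open speak of the compounds shown alone.

Measured in a functional assay on A549 cells (Homo sapiens) for cytotoxicity, read by MTT assay, with a stated time of 48 h; a higher number here means a weaker inhibitor, a lower number a stronger inhibitor:

Compound 1 `COc1ccc(-c2c[nH]c(=O)n2-c2cc(OC)c(OC)c(OC)c2)cc1OC`: > 50000 nM, a limit of the assay and not a number
Compound 2 `COc1cc(-n2c(-c3ccc([N+](=O)[O-])cc3)cn(C(C)=O)c2=O)cc(OC)c1OC`: 49600 nM

Going by the values given here, compound 2 holds the only true number in this assay, and the other value shown is a limit. The next compound to be tested is compound 3 `COc1ccc(-c2cn(C(C)=O)c(=O)n2-c2cc(OC)c(OC)c(OC)c2)cc1OC`. It keeps the acetyl group of compound 2 but carries 3,4-dimethoxyphenyl in place of 4-nitrophenyl on an aromatic carbon. Among the compounds with values here, no two measured compounds differ in just one place, so no measured step shows how large this swap might be. With compound 2 at 49600 nM as the only anchor, no change beyond the usual scatter is expected. In this assay compound 3 may again give only a limit. The estimated change, a 1.4-fold lower number from compound 2 to compound 3 (0.15 log units; within the scatter), is therefore small. For compound 3 the expected value is 35000 nM, with an estimated range of 9000 nM to 80000 nM.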

Compound 3, half-maximal inhibitory concentration: > 50000 nM
Compound 3: only a limit was reported; the forecaster's own chance of this, stated with the estimate: 40%; at least 1.4-fold (0.15 log units) between middle value and limit.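

In this assay, placing 3,4-dimethoxyphenyl instead of 4-nitrophenyl on this aromatic carbon gives a number no lower from compound 2 to compound 3 (the limit leaves the size open), so this change brings no gain in strength. Compound 3 gives > 50000 nM, which is a limit of the assay and not a number. The size of this step cannot be read, and neither can that of the step placing acetyl instead of hydrogen on an aromatic nitrogen, so the series offers little to compare: the limit of > 50000 nM in this assay, at which 2 of the 3 values shown sit.

The compounds shown leave open whether any group on this aromatic carbon can bring the value clearly below the limit. An amine or a carboxylic acid on the phenyl ring at this place, or a plain phenyl, would test this.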